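Methoxy in place of methyl: expectation for compound 3

A few compounds are considered here, and "the series" means these few. Any claim that something is new, unique, unknown or untested is made for them only; others in the source may bear on it.

In a functional assay on HUVEC cells (Homo sapiens) for inhibition, with stated times of 2 h and 72 h (on this read-out lower numbers stand for stronger inhibition and higher numbers for weaker inhibition), compound 1 `COc1cc2nccc(Oc3ccc4c(NC(=O)c5cc(Cl)ccn5)nn(C)c4c3)c2cc1OC` gives 27 nM and compound 2 `COc1cc2nccc(Oc3ccc4c(NC(=O)Nc5ccc(C)cc5)nn(C)c4c3)c2cc1OC` gives 3 nM as the lowest of the two numbers. Among the measured compounds shown here, the one measured step, a 9.0-fold lower number from compound 1 to compound 2 (0.95 log units; beyond the scatter) with (4-methylphenyl)amino in place of 4-chloropyridin-2-yl on a carbonyl carbon, is modest and beyond the scatter. Compound 3 `COc1ccc(NC(=O)Nc2nn(C)c3cc(Oc4ccnc5cc(OC)c(OC)cc45)ccc23)cc1` departs from compound 2 by methoxy in place of methyl on an aromatic carbon, para to a large group (methoxy in place of methyl on an aromatic carbon). For the measured compounds named here, no measured step covers this exchange. The step from compound 1 replaces a whole group, so it bears only loosely and sets an upper guide to size. No shift beyond the scatter is expected in this assay for this smaller change. The estimated step is a 1.3-fold higher number from compound 2 to compound 3 (0.12 log units; within the scatter) with no firm direction. Compound 3 is estimated at 4 nM with an expected range from 1.5 nM to 12 nM in this read-out.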

Compound 3, half-maximal inhibitory concentration: 7 nM
The estimate for compound 3 lay 1.8-fold (0.24 log units) below the measured number; measured number inside the range.
By their numbers in this assay, from the lowest: compound 2; then compound 3; then compound 1.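

In this assay the exchange of methyl for methoxy on the aromatic carbon para to a large group gives a 2.3-fold higher number from compound 2 to compound 3 (0.37 log units; beyond the scatter) and so lies beyond the scatter, which shows that this position responds to a small change, something the earlier pair, differing by a whole group, could not show. The (4-methoxyphenyl)amino group still compares well with 4-chloropyridin-2-yl on the carbonyl carbon, with a 3.9-fold lower number from compound 1 to compound 3 (0.59 log units; beyond the scatter) as the printed step, so the lower number seen on leaving 4-chloropyridin-2-yl holds with methoxy as well as with methyl, though the step is smaller. Nothing measured here accounts for the difference between methyl and methoxy.

The compounds shown leave open how a chlorine, a hydroxy group or a dimethylamino group would read at this same place. Also open, as far as these compounds go, is whether a longer chain such as ethoxy would move the number further in the same direction.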